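Piperidin-4-yl to 4-chlorophenyl on the shared core

This account rests on a few compounds, and the source may have more. Where it says the series, first, only, none or still open, it means among the compounds named here.

Of the compounds shown here, two on the shared core have numbers so far in a physicochemical assay for solubility, using the shake flask method, in simulated intestinal fluid, measured as kinetic solubility, with a stated time of 2 h, at 25 degrees C, at pH 6.5 (on this read-out lower numbers stand for lower solubility and higher numbers for higher solubility), so far as measured. Compound 1 (`Cc1noc(-c2nc(C)c3c(c2N)C(=O)N(Cc2ccc(Oc4ccc(F)cc4)cc2)C3=O)n1`) gives 23800 nM and compound 2 (`Cc1noc(-c2nc(C)c3c(c2N)C(=O)N(CC2CCNCC2)C3=O)n1`) gives 160000 nM as the higher of the two numbers, with the gap between them beyond the scatter. For the measured compounds named here, compound 3 (`Cc1noc(-c2nc(C)c3c(c2N)C(=O)N(Cc2ccc(Cl)cc2)C3=O)n1`) has no measurement yet. Its difference from compound 2 is 4-chlorophenyl in place of piperidin-4-yl on a saturated chain carbon bound to an amide-type nitrogen in a ring on a saturated chain carbon bound to an amide-type nitrogen in a ring. Cut one bond further out, this reads (piperidin-4-yl)methyl to 4-chlorobenzyl. Going by the values given here, compound 1 is the only measured compound without the piperidin-4-yl group, and its 23800 nM anchors the expectation. In this assay a fall beyond the scatter is expected, estimated as a 5.3-fold lower number from compound 2 to compound 3 (0.73 log units; beyond the scatter) on this thin basis. For compound 3 the estimated value is 30000 nM with an expected range from 10000 nM to 90000 nM as a working figure.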

Compound 3, solubility: < 5000 nM
Compound 3 gave a limit, no number; the forecaster's own chance of this, stated with the estimate: 5%; middle value at least 6.0-fold (0.77 log units) away from the limit.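

In this assay compound 3 gives < 5000 nM, a limit of the assay and not a number: the limit of < 5000 nM in this assay, at which 1 of the 3 values shown sits.

For the compounds shown here, on a saturated chain carbon bound to an amide-type nitrogen in a ring, 4-chlorophenyl in place of piperidin-4-yl gives an at least 32-fold lower number from compound 2 to compound 3 (1.50 log units; beyond the scatter), the first single-place step at this position, and its size has only a lower bound. Chloro in place of 4-fluorophenoxy on an aromatic carbon gives an at least 4.7-fold lower number from compound 1 to compound 3 (0.67 log units; beyond the scatter), so the read-out also moves with the group on the aromatic ring, not only with the change of ring.

Going by these compounds, how far compound 3 lies past its limit stays open, and so does the full size of both steps. Also open, on these data alone, is whether a cyclohexyl or a 4-aminophenyl group in this place would stand with compound 2 or with compound 3.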